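A few compounds are considered here, and "the series" means these few. Any claim that something is new, unique, unknown or untested is made for them only; others in the source may bear on it.

Compound 1 `O=C1/C(=C/c2ccc(Cl)cc2)CCC/C1=C\c1ccc([N+](=O)[O-])cc1` gives 9120 nM in a functional assay on MOLT-4 cells (Homo sapiens) for cytotoxicity, with a stated time of 72 h; on this read-out higher numbers stand for weaker inhibition and lower numbers for stronger inhibition. Compound 3 `O=C1/C(=C/c2ccccc2)CCC/C1=C\c1ccc([N+](=O)[O-])cc1` differs from it by hydrogen in place of chloro on an aromatic carbon and gives 8350 nM in this assay, so that change produced a 1.1-fold lower number from compound 1 to compound 3 (0.04 log units; within the scatter). Compound 2 `O=C1/C(=C/c2ccc(Cl)cc2)CCC/C1=C\c1ccccc1[N+](=O)[O-]` gives 3860 nM in this assay; the difference between its core and the core of compound 1 is not broken down here, and its value is the lowest of the three measured. Compound 4 `O=C1/C(=C/c2ccccc2)CCC/C1=C\c1ccccc1[N+](=O)[O-]` has not yet been measured in this assay. It differs from compound 2 by hydrogen in place of chloro on an aromatic carbon, the same change, at the same place, as that made from compound 1 to compound 3. Because that earlier step a 1.1-fold lower number from compound 1 to compound 3 (0.04 log units; within the scatter) lay within the scatter, the expected step for compound 4 is a 1.1-fold lower number from compound 2 to compound 4 (0.03 log units; within the scatter). Compound 4 is therefore estimated at 3600 nM, with a likely range from 1600 nM to 8000 nM.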

Compound 4, half-maximal inhibitory concentration: 1480 nM
Compound 4: the middle estimate sits 2.4-fold (0.39 log units) above what was measured, outside the stated range (below it).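

In this assay, going from 4-chlorophenyl to phenyl on the core of compound 2 gave a 2.6-fold lower number from compound 2 to compound 4 (0.42 log units; beyond the scatter). Set beside the earlier step, this result cannot be called different, so the data give no firm sign that the effect of this change depends on the core: the same change on two cores in this assay, a 1.1-fold lower number (0.04 log units; within the scatter) from compound 1 to compound 3 and a 2.6-fold lower number (0.42 log units; beyond the scatter) from compound 2 to compound 4, 2.4-fold (0.38 log units) apart, within the scatter of two such steps This does not show that the two steps are equal, and two cores are too few to fix a size for the change across the series.

The compounds shown leave open how a fluoro, a methoxy or an amine in place of the chloro would read on either core. They also leave open whether the same holds on cores carrying a nitrile instead of the nitro group.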